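Benzyl amine variation on a shared diamino core

The compounds below may be only part of what the source reports. "The series", "measured", "known", "first", "only" and "open" are said of these compounds alone.

Measured so far:
compound 1 `Nc1cc(N)c2nc(-c3ccccc3)c(Oc3ccc(Cl)c(Cl)c3)nc2c1` — 15800 nM
compound 2 `Nc1cc(N)c2nc(-c3ccccc3)c(NCc3ccc(Cl)c(Cl)c3)nc2c1` — 11500 nM
compound 3 `COc1cc(CNc2nc3cc(N)cc(N)c3nc2-c2ccccc2)cc(OC)c1OC` — 9770 nM

All three numbers come from a functional assay on HCT-116 cells (Homo sapiens) for inhibition, read by sulforhodamine B assay, with a stated time of 48 h; on this read-out higher numbers stand for weaker inhibition of growth and lower numbers for stronger inhibition of growth. In this assay compound 1 gives 15800 nM, compound 2 gives 11500 nM and compound 3 gives 9770 nM. The number of compound 2 sits between those of compound 1 and compound 3, and both gaps are within the usual scatter of repeated measurements, so no ordering among the three can be read from these values.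

Compound 4 `COc1ccc(CNc2nc3cc(N)cc(N)c3nc2-c2ccccc2)cc1` is the next member. Relative to compound 2 it carries 4-methoxyphenyl in place of 3,4-dichlorophenyl on a saturated chain carbon bound to a nitrogen on an aromatic ring. Among the compounds with values here, no pair of measured compounds differing in one place is available to calibrate such a change. Given that compound 2 and compound 3 agree within the scatter despite different substitution on the benzyl group, the step is expected to be small: a 1.1-fold lower number from compound 2 to compound 4 (0.04 log units; within the scatter), most likely none beyond the scatter. Compound 4 is estimated at 10500 nM, with a range from 4500 nM to 25000 nM.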

Compound 4, concentration for 50% growth inhibition: 14500 nM
Beside the measured number, compound 4's estimate is 1.4-fold (0.14 log units) below it; the measured number falls inside the stated range.
By their numbers in this assay, from the lowest: compounds 3, 2, 4 and 1 (each within the scatter of the next).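

Within the data shown here, the exchange of 3,4-dichlorophenyl for 4-methoxyphenyl on a saturated chain carbon bound to a nitrogen on an aromatic ring gives the first one-place step in this assay, namely a 1.3-fold higher number from compound 2 to compound 4 (0.10 log units; within the scatter). At this position, then, removing both chlorines and adding a methoxy group leaves the growth-inhibition number unchanged within the scatter, so this change gives no handle on the read-out. No measurement bears on this result.

As far as these compounds go, whether anything at this position can move the number beyond the scatter remains open, for instance a carboxylic acid or an amine on the ring, or a longer chain in place of the benzyl link. Also open, from the compounds shown here alone, is whether the phenyl group and the two amino groups on the shared core matter more.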